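The source may hold more compounds than are shown below. What is called first, only, known or untested is meant among the compounds shown, and "the series" means these compounds.

In an ADME assay on Vero cells (Chlorocebus sabaeus) for cytotoxicity, read by sulforhodamine B assay, with a stated time of 48 h (a lower number here means that less compound is tolerated, a higher number that more compound is tolerated), compound 1 `O=C(Nc1ncc([N+](=O)[O-])s1)NC1CCCCC1` gives only a limit, > 1000000 nM. Compound 2 `O=C(Nc1ccccc1)Nc1ncc([N+](=O)[O-])s1` also gives only a limit, > 1000000 nM. Compound 3 `O=C(Nc1ccc(Cl)cc1)Nc1ncc([N+](=O)[O-])s1` likewise stands at a limit and not a number, > 1000000 nM. For the measured compounds named here, the series so far therefore offers only (the limit of > 1000000 nM in this assay, at which 3 of the 3 values shown sit).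

Compound 4 `O=C(Nc1ccc(F)cc1)Nc1ncc([N+](=O)[O-])s1` differs from compound 3 by fluoro in place of chloro on an aromatic carbon, with fluoro in place of chloro on an aromatic carbon, para to a large group. The closest measured change is a step that the two limits leave unreadable from compound 2 to compound 3, and the other is a step that the two limits leave unreadable from compound 1 to compound 2. Neither has a size to carry over, though both leave the reading at the limit.

The expected change is a number no higher from compound 3 to compound 4 (the limit leaves the size open), with nothing anticipated beyond the scatter in this assay. For compound 4 the estimated value is 1000000 nM, within an expected range of 400000 nM to 2000000 nM.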

Compound 4, half-maximal cytotoxic concentration: > 1000000 nM
Compound 4: a limit, no number (the forecaster's own chance of this, stated with the estimate: 80%); the middle value lies on the limit itself.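

In this assay compound 4 gives > 1000000 nM, a limit and not a number, so its steps from compound 2 and from compound 3 cannot be read. The compounds shown leave open whether any of these changes alters tolerance, because all readings share one limit: the limit of > 1000000 nM in this assay, at which 4 of the 4 values shown sit.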